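The source may hold more compounds than are shown below. What is called first, only, known or untested is meant among the compounds shown, and "the series" means these compounds.

Among the compounds with values here, compound 2 `CC(C)(C)OC(=O)/C=C1/C(=O)Nc2ccc(OC(F)(F)F)cc21` is one of two compounds so far measured in a functional assay on HL-60 cells (Homo sapiens) for cytotoxicity, read by CCK-8 assay, with a stated time of 72 h; on this read-out lower numbers stand for stronger inhibition and higher numbers for weaker inhibition. In this assay compound 2 gives 4480 nM. Within the data shown here, its only companion is compound 1 `Cc1ccc2c(c1)/C(=C\C(=O)OC(C)(C)C)C(=O)N2`, which in this assay gives 5000 nM, and the one measured step, a 1.1-fold lower number from compound 1 to compound 2 (0.05 log units; within the scatter), leaves the two numbers indistinguishable within the scatter; compound 2 thus stands alongside compound 1 rather than apart from it.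

The unmeasured compound 3 `CC(C)(C)OC(=O)/C=C1/C(=O)Nc2ccc([N+](=O)[O-])cc21` differs from compound 2 in one place: nitro in place of trifluoromethoxy on an aromatic carbon. Among the measured compounds shown here, the single measured step bears on this change directly, since it too swaps the group on an aromatic carbon of the shared core, meta to a fused ring and para to a fused ring, and it was a 1.1-fold lower number from compound 1 to compound 2 (0.05 log units; within the scatter). On that basis no move beyond the scatter in this assay is expected for compound 3, in either direction. Compound 3 is accordingly expected to give 4500 nM in this assay, within a range from 1500 nM to 13000 nM. The estimated step of a 1.0-fold higher number from compound 2 to compound 3 (0.00 log units; within the scatter) is therefore expected to be small.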

Compound 3, half-maximal inhibitory concentration: 9860 nM
Compound 3: middle estimate off by 2.2-fold (0.34 log units), on the low side; measured number inside the range.
By their numbers in this assay, from the lowest: compounds 2, 1 and 3 (each within the scatter of the next, the first and the last beyond it).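

Within the data shown here, at the aromatic carbon meta to a fused ring and para to a fused ring, the change from trifluoromethoxy to nitro yields the first step beyond the scatter in this assay (a 2.2-fold higher number from compound 2 to compound 3 (0.34 log units; beyond the scatter)), so the number at this position does respond to the group placed there, if only modestly. Nitro in place of methyl gives a 2.0-fold higher number from compound 1 to compound 3 (0.29 log units; within the scatter), so among these three groups only trifluoromethoxy and nitro are separated, while methyl stays within the scatter of both and the series shows no graded order. Nothing available on these compounds beyond the numbers themselves accounts for the step from trifluoromethoxy to nitro.

Going by these compounds, the three compounds carry only methyl, trifluoromethoxy and nitro at this position, all without net charge, so it remains open whether an amine, a carboxylic acid or a longer chain there would move the number further in either direction. Also open, on these data alone, is whether the step seen with nitro would persist if the tert-butyl ester on the shared core were replaced by a carboxylic acid or an amide.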